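The compounds below may be only part of what the source reports. "The series", "measured", "known", "first", "only" and "open" are said of these compounds alone.

Of the compounds shown here, three share one core and have been measured in a functional assay on Ehrlich cells (Mus musculus) for antiproliferative activity, read by trypan blue exclusion, with a stated time of 2 h; a higher number here means a weaker inhibitor, a lower number a stronger inhibitor. Compound 1 `N#CC1=C(N)N(c2ccc(S(N)(=O)=O)cc2)C2=C(C(=O)CCC2)C1c1ccccc1` gives only a limit of the assay, > 100 ug/mL. Compound 2 `Cc1ccc(C2C(C#N)=C(N)N(c3ccc(S(N)(=O)=O)cc3)C3=C2C(=O)CCC3)cc1` gives 50 ug/mL. Compound 3 `N#CC1=C(N)N(c2ccc(S(N)(=O)=O)cc2)C2=C(C(=O)CCC2)C1c1ccc(O)cc1` gives 3 ug/mL and stands lowest of the two numbers, with compound 2 nearest; the step of a 17-fold lower number from compound 2 to compound 3 (1.22 log units; beyond the scatter) lies beyond the scatter, and an at least 33-fold lower number from compound 1 to compound 3 (1.52 log units; beyond the scatter) is at least as large, while an at least 2.0-fold lower number from compound 1 to compound 2 (0.30 log units; that floor lies within the scatter) lies within it.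

Compound 4 `N#CC1=C(N)N(c2ccc(S(N)(=O)=O)cc2)C2=C(C(=O)CCC2)C1/C=C/c1ccccc1` differs from compound 3 by 2-phenylethenyl in place of 4-hydroxyphenyl on a saturated ring carbon. The hydroxy group is thus given up, and both measured steps that reached compound 3 turned on that group: they show that a phenyl ring without it, or bearing methyl, leaves a far higher number. The step of a 13-fold higher number from compound 3 to compound 4 (1.12 log units; beyond the scatter) is therefore expected to be a sizeable rise. That expectation rests on the steps of a 17-fold lower number from compound 2 to compound 3 (1.22 log units; beyond the scatter) and an at least 33-fold lower number from compound 1 to compound 3 (1.52 log units; beyond the scatter), which were large. For compound 4 the estimate is 40 ug/mL, with a range from 8 ug/mL to 150 ug/mL, and a real chance that compound 4 again returns only a limit.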

Compound 4, half-maximal inhibitory concentration: > 100 ug/mL
Compound 4 gave a limit, no number; the forecaster's own chance of this, stated with the estimate: 30%; middle value at least 2.5-fold (0.39 log units) away from the limit.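

In this assay compound 4 gives only a limit of the assay, > 100 ug/mL. Going by these compounds alone, the step of an at least 33-fold higher number from compound 3 to compound 4 (1.52 log units; beyond the scatter) shows that the low number of compound 3 does not survive when 2-phenylethenyl, which keeps an aromatic ring but has no hydroxy group, replaces 4-hydroxyphenyl on this saturated ring carbon; the earlier steps had changed only what the aromatic ring carried. The step of an at least 2.0-fold higher number from compound 2 to compound 4 (0.30 log units; that floor lies within the scatter) has a floor within the scatter and sets no order, and the step between the two limits cannot be read: the limit of > 100 ug/mL in this assay, at which 2 of the 4 values shown sit.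

As far as these compounds go, whether the loss follows from the missing hydroxy group or from the ethenyl unit stays open, and a 2-(4-hydroxyphenyl)ethenyl group on this carbon would separate the two. From the compounds shown here alone, it is also open whether an amine or a carboxylic acid in place of the hydroxy group would keep a number as low as that of compound 3.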